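Aryl variation on the piperazine nitrogen: toward compound 4

This account rests on a few compounds, and the source may have more. Where it says the series, first, only, none or still open, it means among the compounds named here.

Measured so far:
Compound 1, `COc1ccc(N2CCN(Cc3csc(N)c3C(=O)c3ccc(Cl)cc3)CC2)cc1`, gives 0% in a functional assay on CHO cells with adenosine receptor A1 (Homo sapiens) as the target, read by cAMP accumulation and immunoassay, with a stated time of 6 min, tested at 0.1 uM; a lower number here means a stronger effect, a higher number a weaker effect of the compound at the concentration tested.
Compound 2, `Nc1scc(CN2CCN(c3ccc([N+](=O)[O-])cc3)CC2)c1C(=O)c1ccc(Cl)cc1`, gives -13% in this assay.
Compound 3, `Nc1scc(CN2CCN(c3ccncc3)CC2)c1C(=O)c1ccc(Cl)cc1`, gives 1.4% in this assay.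

Compound 1 holds the second highest of the three numbers. Its nearest neighbour is compound 3, with the step of a number 1.4 percentage points higher from compound 1 to compound 3 (within the scatter), which stays within the scatter. Its furthest is compound 2, with the step of a number 13 percentage points lower from compound 1 to compound 2 (beyond the scatter), a modest lowering beyond the scatter.

Compound 4, `Nc1scc(CN2CCN(c3ccccc3Cl)CC2)c1C(=O)c1ccc(Cl)cc1`, is the next member. Relative to compound 1 the change is 2-chlorophenyl in place of 4-methoxyphenyl on an amine nitrogen in a ring. Both measured steps from compound 1 bear on it, since each also exchanges the group on the same ring nitrogen of the shared core: one left the number within the scatter, the other lowered it modestly. Neither involved a 2-chlorophenyl, so the present exchange of one carbon-only six-membered aromatic ring for another rests only on that range. The expectation is therefore a small step, most likely within the scatter, with a modest lowering as the less likely outcome.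

Compound 4 is expected to give -3%, in a range from -18% to 12%. This corresponds to an expected step of a number 3 percentage points lower from compound 1 to compound 4 (within the scatter).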

Compound 4, a percentage reported as activity, at one concentration (the size of the read-out at that concentration, not a potency): 2%
The estimate for compound 4 lay 5 percentage points below the measured number; the measured number falls inside the stated range.
By their numbers in this assay, from the lowest: compound 2; then compounds 1, 3 and 4 (each within the scatter of the next).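

In this assay, 2-chlorophenyl on the ring nitrogen gives a number 2 percentage points higher from compound 1 to compound 4 (within the scatter) against 4-methoxyphenyl and a number 0.6 percentage points higher from compound 3 to compound 4 (within the scatter) against pyridin-4-yl, so this third group joins the other two in a set that the read-out does not separate. For the compounds shown here, the set now spans a chlorine-bearing ring, a methoxy-bearing ring and a ring with nitrogen in it, and the 4-nitrophenyl of compound 2 is the one group that goes against this flat picture, with a number 15 percentage points higher from compound 2 to compound 4 (beyond the scatter). Nothing at hand explains either the flat set or the position of compound 2.

The compounds shown leave open whether the lower number of compound 2 belongs to the nitro group alone or would also appear with a nitrile or a trifluoromethyl on the same phenyl ring. They also leave open whether an aromatic ring on this nitrogen matters at all, which a cyclohexyl or a plain methyl there would test, and the read-out at a single concentration gives no potency for any of the four compounds.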